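Methylating a triazole thiol on a shared phenol core

This account rests on a few compounds, and the source may have more. Where it says the series, first, only, none or still open, it means among the compounds named here.

Measured so far:
compound 1 `Cn1ccnc1Sc1cnc(-c2ccc(N)cc2)nc1-c1ccccc1O`: 80100 ug/mL
compound 2 `CC(C)(C)c1ncc(Sc2nc[nH]n2)c(-c2ccccc2O)n1`: 160000 ug/mL
compound 3 `Cc1ncc(Sc2nccn2C)c(-c2ccccc2O)n1`: 577000 ug/mL

Three compounds share a core bearing a hydroxyphenyl group and a thioether. In an ADME assay on MDCK cells (Canis lupus familiaris) for cytotoxicity (on this read-out higher numbers stand for lower toxicity in this test and lower numbers for higher toxicity in this test), compound 2 gives 160000 ug/mL, the second highest of the three numbers; it sits within the scatter of compound 1 and beyond the scatter below compound 3. Within the data shown here, the only step between neighbours, a 7.2-fold higher number from compound 1 to compound 3 (0.86 log units; beyond the scatter), changes a group on an aromatic carbon, not the thioether end. The step to the unmeasured compound 4 `Cn1cnnc1Sc1cnc(C(C)(C)C)nc1-c1ccccc1O` is 4-methyl-4H-1,2,4-triazol-3-yl in place of 1H-1,2,4-triazol-3-yl on a sulfur. Among the measured compounds shown here, no measured pair speaks to this change, so no movement beyond the scatter is expected. Compound 4 is therefore estimated at 160000 ug/mL (range 60000 ug/mL to 420000 ug/mL), an expected step of no change at the digits printed from compound 2 to compound 4 (within the scatter).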

Compound 4, half-maximal cytotoxic concentration: 160000 ug/mL
Compound 4: the middle estimate sits on the measured number at the digits printed; measured number inside the range.
By their numbers in this assay, from the lowest: compounds 1, 2 and 4 (each within the scatter of the next); then compound 3.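

In this assay, among these compounds, the thioether end is changed for the first time, as the only earlier step altered a group on an aromatic carbon. Here 4-methyl-4H-1,2,4-triazol-3-yl in place of 1H-1,2,4-triazol-3-yl on a sulfur gives no change at the digits printed from compound 2 to compound 4 (within the scatter) and so leaves the read-out in place on this core. Nothing measured here offers an explanation for this result.

On these data alone, whether an ethyl group, a longer chain or a carboxylic acid in place of that methyl would also leave the number in place remains open. So does whether the same change reads alike with methyl or 4-aminophenyl on the aromatic carbon, the groups carried by compound 3 and compound 1.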